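The compounds below may be only part of what the source reports. "The series", "measured", "known", "first", "only" and "open" are said of these compounds alone.

Measured compounds:
- compound 1 `COc1ccc2[nH]c(C)c(C3=C(Br)C(=O)C(c4c(-c5ccccc5)[nH]c5ccccc45)=C(Br)C3=O)c2c1` — 2.57 ug/mL
- compound 2 `Cc1[nH]c2ccccc2c1C1=C(Br)C(=O)C(c2c(-c3ccccc3)[nH]c3ccccc23)=C(Br)C1=O` — 3.02 ug/mL

Of the compounds shown here, two sharing one core have been measured in a functional assay on MCF7 cells (Homo sapiens) for antiproliferative activity, read by CCK-8 assay, with a stated time of 48 h; on this read-out lower numbers stand for stronger inhibition and higher numbers for weaker inhibition. Compound 1 gives 2.57 ug/mL, the lower of the two numbers; compound 2 gives 3.02 ug/mL. Within the data shown here, the single measured step, a 1.2-fold higher number from compound 1 to compound 2 (0.07 log units; within the scatter), removes a methoxy from the core and lies within the scatter, so the two compounds cannot be ranked against each other.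

Compound 3 `COc1ccc2[nH]c(C)c(C3=C(Br)C(=O)C(c4c(-c5ccc(C)cc5)[nH]c5ccccc45)=C(Br)C3=O)c2c1` is the next compound to be tested. It differs from compound 1 by methyl in place of hydrogen on an aromatic carbon. Among the measured compounds shown here, no measured step alters this same position; the only step available, a 1.2-fold higher number from compound 1 to compound 2 (0.07 log units; within the scatter), concerns a different part of the molecule and shows how little a small change at the edge of this core has moved the read-out so far. On that basis, and with nothing pointing in either direction, the expectation is a step in this assay that stays within the scatter, a 1.0-fold higher number from compound 1 to compound 3 (0.01 log units; within the scatter). Compound 3 is therefore expected to give about 2.6 ug/mL, most likely between 1.2 ug/mL and 5.5 ug/mL.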

Compound 3, half-maximal inhibitory concentration: 2.56 ug/mL
Compound 3: middle estimate off by 1.0-fold (0.01 log units), on the high side, and the stated range covers the measured number.
By their numbers in this assay, from the lowest: compounds 3, 1 and 2 (each within the scatter of the next).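

In this assay, the step from phenyl to 4-methylphenyl gives a 1.0-fold lower number from compound 1 to compound 3 (0.00 log units; within the scatter), so compound 1 and compound 3 cannot be ranked against each other. Among these compounds, the earlier step concerned only the loss of the methoxy, whereas this is the first reading at the phenyl group: one added methyl on this six-membered aromatic ring of carbon only, para to a large group, leaves the number within the usual scatter of repeated measurements. This is one small change at one place, and no separate measurement is available to explain the outcome.

Whether an amine, a carboxylic acid or a longer chain at the same place would also leave the read-out within the scatter remains an open question, as a methyl is the only group shown there besides hydrogen. As far as these compounds go, it is also open whether the same methyl would give a similar result on the core of compound 2, which carries hydrogen in place of the methoxy.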